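Methoxy for methyl on the fused-ring core

This account rests on a few compounds, and the source may have more. Where it says the series, first, only, none or still open, it means among the compounds named here.

Measured compounds:
compound 1 `Cc1oc(/C=C/C(=O)O)cc1Cc1ccc2c(c1)C(C)(C)CCC2(C)C` — > 1000 nM
compound 2 `Cc1cc2c(cc1C1CCCc3oc(/C=C/C(=O)O)cc31)C(C)(C)CCC2(C)C` — > 10000 nM

Neither value shown so far is a number. In a functional assay on cells (Fibroblast) with retinoic acid receptor alpha (Homo sapiens) as the target (on this read-out lower numbers stand for an effect already at smaller amounts and higher numbers for an effect only at larger amounts of compound), compound 1 sits at a limit of the assay, (the limit of > 1000 nM in this assay, at which 1 of the 2 values shown sits). In this assay compound 2 likewise sits at a limit, (the limit of > 10000 nM in this assay, at which 1 of the 2 values shown sits). Among the measured compounds shown here, no step between measured compounds that differ in one place is available, so the two values say only that both compounds produced no measurable effect within the range tested, and nothing about how they compare with each other.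

Compound 3 `COc1cc2c(cc1C1CCCc3oc(/C=C/C(=O)O)cc31)C(C)(C)CCC2(C)C` has not been measured in this assay. It differs from compound 2 in one place: methoxy in place of methyl on an aromatic carbon.

For the measured compounds named here, with compound 2 at a limit and no measured step to rest on, no change beyond the scatter is expected; the estimated step is a step that the limit leaves unreadable from compound 2 to compound 3. In this assay compound 3 is therefore expected at about 12000 nM, within 2000 nM to 60000 nM, and most likely again reported only as a limit.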

Compound 3, half-maximal effective concentration: > 10000 nM
Compound 3: no number, only a limit; the forecaster's own chance of this, stated with the estimate: 70%; the middle value is on the limit's open side.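

Compound 2 and compound 3 both end at the same limit in this assay, and no step from methyl to methoxy can be read between them: the limit of > 10000 nM in this assay, at which 2 of the 3 values shown sit.

The compounds shown leave open whether methoxy in place of methyl on the aromatic carbon changes anything in this assay, and at what concentration any of the three compounds would give an effect.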